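A few compounds are considered here, and "the series" means these few. Any claim that something is new, unique, unknown or untested is made for them only; others in the source may bear on it.

Measured so far:
- compound 1 `O=C(/C=C/c1ccc2c(c1)B(O)OC2)c1cccs1`: 10400 nM
- compound 2 `O=C(/C=C/c1ccc2c(c1)B(O)OC2)c1ccc(Cl)cc1`: 3700 nM

Of the compounds shown here, two sharing one core have been tested in a functional assay on SK-OV-3 cells (Homo sapiens) for cytotoxicity, read by MTT assay, with a stated time of 48 h; on this read-out higher numbers stand for weaker inhibition and lower numbers for stronger inhibition. Compound 1 `O=C(/C=C/c1ccc2c(c1)B(O)OC2)c1cccs1` gives 10400 nM, and compound 2 `O=C(/C=C/c1ccc2c(c1)B(O)OC2)c1ccc(Cl)cc1` gives 3700 nM, the lower of the two numbers. Among the measured compounds shown here, the one step between them, a 2.8-fold lower number from compound 1 to compound 2 (0.45 log units; beyond the scatter), shows that swapping the group on the carbonyl carbon moved the number by a modest amount.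

Compound 3 `O=C(/C=C/c1ccc2c(c1)B(O)OC2)c1ccc(I)cc1` is the next compound, and it differs from compound 2 by iodo in place of chloro on an aromatic carbon. For the measured compounds named here, no step among the measured compounds concerns a change of this kind; the only known step touches a different group and so bears on this one only loosely. With nothing pointing strongly either way, for compound 3 a step of a 1.2-fold lower number from compound 2 to compound 3 (0.09 log units; within the scatter) is expected, small and within the scatter. The estimate for compound 3 in this assay is therefore 3000 nM, with a range from 1200 nM to 8000 nM.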

Compound 3, half-maximal inhibitory concentration: 4200 nM
Beside the measured number, compound 3's estimate is 1.4-fold (0.15 log units) below it; low and high end bracket the measured number.
By their numbers in this assay, from the lowest: compounds 2 and 3 (each within the scatter of the next); then compound 1.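

In this assay, the swap of chloro for iodo on the aromatic carbon para to a large group comes to a 1.1-fold higher number from compound 2 to compound 3 (0.06 log units; within the scatter) and so gives no readable difference between these two halogens at this position. The gap to the thiophen-2-yl compound also appears with 4-iodophenyl, as a 2.5-fold lower number from compound 1 to compound 3 (0.39 log units; beyond the scatter) on the same read-out, so it is not tied to chloro alone. No outside measurement offers an explanation for these numbers.

Still open, going by these compounds, is whether a group other than a halogen at this position, such as an amine, a carboxylic acid or a methoxy group, would give a number that differs from those of compound 2 and compound 3. Also open, on these data alone, is how a plain hydrogen at this position would compare with chloro and iodo.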